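A few compounds are considered here, and "the series" means these few. Any claim that something is new, unique, unknown or untested is made for them only; others in the source may bear on it.

In a functional assay on HCT-116 cells (Homo sapiens) for antiproliferative activity, read by MTT assay, with a stated time of 48 h (a lower number here means a stronger inhibitor, a higher number a weaker inhibitor), compound 1 (`CCCCC(CCO)n1cnc2c(N)ncnc21`) gives > 50000 nM as a limit of the assay and not a number. Among the measured compounds shown here, compound 2 (`CCCCCCCCC(CCO)n1cnc2c(OC)ncnc21`) gives 12800 nM as the only actual number so far. Compound 3 (`CCCCCCCCC(CCO)n1cnc2c(N)ncnc21`) differs from compound 2 by amino in place of methoxy on an aromatic carbon. For the measured compounds named here, no measured step guides this change, and no shift beyond the usual scatter is expected in this assay in either direction. The estimated change is a 1.2-fold higher number from compound 2 to compound 3 (0.07 log units; within the scatter) and would leave the two compounds on a par. Compound 3 is expected at 15000 nM with an estimated range from 5000 nM to 45000 nM in this measurement.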

Compound 3, half-maximal inhibitory concentration: 11600 nM
Beside the measured number, compound 3's estimate is 1.3-fold (0.11 log units) above it; measured number inside the range.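

In this assay, amino and methoxy on an aromatic carbon leave the two compounds on a par, a 1.1-fold lower number from compound 2 to compound 3 (0.04 log units; within the scatter), so this exchange alone does not separate them. Butyl in place of hydrogen on a saturated chain carbon, five bonds along the chain from an aromatic nitrogen, gives the only step beyond the scatter, an at least 4.3-fold lower number from compound 1 to compound 3 (0.63 log units; beyond the scatter). Compound 1 stands at a limit of the assay and not a number: the limit of > 50000 nM in this assay, at which 1 of the 3 values shown sits.

The compounds shown leave open whether a longer chain would shift the number further. They also leave open whether chlorine or a dimethylamino group on that aromatic carbon would stay on a par with amino and methoxy.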